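The source may hold more compounds than are shown below. What is called first, only, known or untested is meant among the compounds shown, and "the series" means these compounds.

Three related compounds of a shared core were tested in an ADME assay on RAW264.7 cells (Mus musculus) for cytotoxicity, read by MTT assay, with a stated time of 24 h, tested at 5 ug/mL; a higher number here means a weaker effect of the compound at the concentration tested, a lower number a stronger effect. Compound 3 `COc1ccc(/C=C/C(=O)c2cccc(O)c2)cc1OC` gives 83.8%; compound 1 `COc1cc(/C=C/C(=O)c2cccc(O)c2)ccc1O` gives 63.8%. These two differ in one place, (hydrogen in place of methyl on an oxygen on an aromatic ring), and that change made a step of a number 20 percentage points lower from compound 3 to compound 1 (beyond the scatter). Compound 2 `COc1ccc(/C=C/C(=O)c2ccc(OC)c(OC)c2)cc1OC` gives 81.3% in this assay; the difference between the core of compound 2 and the core of compound 3 is not broken down here. Compound 4 `COc1ccc(/C=C/C(=O)c2ccc(OC)c(OC)c2)cc1O` has not yet been measured. It differs from compound 2 in one place, (hydrogen in place of methyl on an oxygen on an aromatic ring), which is the same change as that from compound 3 to compound 1. The step is expected to be similar in size, a number 17.3 percentage points lower from compound 2 to compound 4 (beyond the scatter), because a number 20 percentage points lower from compound 3 to compound 1 (beyond the scatter) was seen for the same change, though it rests on a single pair. Compound 4 is therefore expected to give about 64%, likely between 50% and 80%.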

Compound 4, a percentage reported as activity, at one concentration (the size of the read-out at that concentration, not a potency): 73%
Compound 4: middle estimate off by 9 percentage points, on the low side; the range from low to high includes it.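

In this assay, replacing methoxy with hydroxy on the second core gave a number 8.3 percentage points lower from compound 2 to compound 4 (within the scatter). Set beside the earlier pair, the two steps cannot be told apart: the same change on two cores in this assay, a number 20 percentage points lower (beyond the scatter) from compound 3 to compound 1 and a number 8.3 percentage points lower (within the scatter) from compound 2 to compound 4, 11.7 percentage points apart, within the scatter of two such steps. For the compounds shown here, this fits the change carrying over from one core to the other, but it does not establish that, since only two pairs are available and the new step alone cannot be separated from ordinary variation between repeats.

The compounds shown leave open how a longer chain on that oxygen, such as ethyl, or an amine in place of the hydroxy would behave. As far as these compounds go, whether the change would carry over to cores beyond these two also remains open.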